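This account rests on a few compounds, and the source may have more. Where it says the series, first, only, none or still open, it means among the compounds named here.

Measured so far:
- Compound 1 `CC1=C(C(=O)OCc2ccccc2)C(c2ccc(Cl)cc2Cl)NC(=O)N1CCCC(=O)OCc1ccccc1` gives > 100000 nM, a limit.
- Compound 2 `CC1=C(C(=O)OCc2ccccc2)C(c2ccc(Cl)cc2Cl)NC(=O)N1CCCC(=O)OCC1CC1` gives > 100000 nM, a limit.
- Compound 3 `C/C=C/COC(=O)CCCN1C(=O)NC(c2ccc(Cl)cc2Cl)C(C(=O)OCc2ccccc2)=C1C` gives > 100000 nM, a limit.

In an ADME assay on MCF7 cells (Homo sapiens) for cytotoxicity, read by CellTiter-Glo, with a stated time of 24 h (on this read-out higher numbers stand for weaker inhibition of growth and lower numbers for stronger inhibition of growth), compound 3 gives > 100000 nM, which is a limit of the assay and not a number. It has no company of measured numbers to be ranked against: the limit of > 100000 nM in this assay, at which 3 of the 3 values shown sit.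

Compound 4 `COC(=O)CCCN1C(=O)NC(c2ccc(Cl)cc2Cl)C(C(=O)OCc2ccccc2)=C1C` differs from compound 3 at one place: hydrogen in place of prop-1-en-1-yl on a saturated chain carbon bound to an oxygen next to a carbonyl group. In words, hydrogen replaces prop-1-en-1-yl on a saturated chain carbon bound to an oxygen next to a carbonyl group, so but-2-en-1-yl becomes methyl.

Three measured steps change this same place: a step that the two limits leave unreadable from compound 1 to compound 3, a step that the two limits leave unreadable from compound 2 to compound 3 and a step that the two limits leave unreadable from compound 1 to compound 2. None of them has a readable size, so they point to no direction for the new change.

The estimated step, with no change beyond the scatter, is a number no higher from compound 3 to compound 4 (the limit leaves the size open). Compound 4 is expected at 100000 nM, within an estimated range of 40000 nM to 200000 nM. Compound 4 will probably be reported as a limit as well.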

Compound 4, concentration for 50% growth inhibition: > 300000 nM
Compound 4 ended at the assay's limit; the forecaster's own chance of this, stated with the estimate: 85%; middle value at least 3.0-fold (0.47 log units) away from the limit.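

Among these compounds, the results for compound 1, compound 2, compound 3 and compound 4 are all limits of the assay and not numbers, and no step among them can be read. The compounds shown leave open how strongly any of them inhibits growth, and whether changing this ester group alters that at all.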